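The source may hold more compounds than are shown below. What is called first, only, known or untested is meant among the compounds shown, and "the series" means these compounds.

The measured compounds are:
compound 1, `OC[C@H]1OC(n2cnc3c(-c4cc[nH]c4)ncnc32)[C@H](O)[C@@H]1O`, 3200 nM
compound 2, `OC[C@H]1OC(n2cnc3c(-c4ccoc4)ncnc32)[C@H](O)[C@@H]1O`, 3300 nM

Compound 2 stands at the highest of the two numbers recorded in a functional assay on HL-60 cells (Homo sapiens) for inhibition (on this read-out lower numbers stand for stronger inhibition and higher numbers for weaker inhibition), and its nearest neighbour is compound 1, whose value lies within the scatter of that of compound 2, so the two cannot be separated on this read-out. The step from compound 2 to compound 3, `Cc1ccsc1-c1ncnc2c1ncn2C1O[C@H](CO)[C@@H](O)[C@H]1O`, is 3-methylthiophen-2-yl in place of furan-3-yl on an aromatic carbon. Among the measured compounds shown here, only one measured step bears on this change, and it exchanges one five-membered aromatic ring for another on the aromatic carbon: a 1.0-fold higher number from compound 1 to compound 2 (0.01 log units; within the scatter). That exchange left the number unchanged beyond the scatter. For the measured compounds named here, the change to compound 3 brings sulfur in place of oxygen and adds a methyl group, for which no measured step exists, so the expectation rests on the single exchange and carries a wider range. Compound 3 is expected to give 3300 nM in this assay, with a range from 1500 nM to 7500 nM. This estimate means a step of no change at the digits printed from compound 2 to compound 3 (within the scatter), expected to remain within the scatter.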

Compound 3, half-maximal inhibitory concentration: 4500 nM
For compound 3 the middle estimate is 1.4-fold (0.13 log units) below the measured one; measured number inside the range.
By their numbers in this assay, from the lowest: compounds 1, 2 and 3 (each within the scatter of the next).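

The earlier pair only exchanged one unsubstituted five-membered aromatic ring for another on this aromatic carbon. Compound 3 goes further, with sulfur as the hetero atom, a methyl group on the ring and a different point of attachment, yet in this assay the result stays within the scatter (a 1.4-fold higher number from compound 2 to compound 3 (0.13 log units; within the scatter)) and the same holds against the pyrrole (a 1.4-fold higher number from compound 1 to compound 3 (0.15 log units; within the scatter)). No information is available to explain this result.

Because sulfur, the methyl group and the point of attachment all change together in compound 3, the three compounds cannot show what each contributes alone or whether any of them offset one another, a question that thiophen-2-yl without the methyl group or 3-methylfuran-2-yl would address. They also leave open whether this position stays as flat on the read-out for groups other than five-membered aromatic rings, such as phenyl, an amine such as morpholine, a carboxylic acid or a longer chain such as n-butyl.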